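This account rests on a few compounds, and the source may have more. Where it says the series, first, only, none or still open, it means among the compounds named here.

Measured compounds in a functional assay on DU-145 cells (Homo sapiens) for inhibition, read by trypan blue exclusion, with a stated time of 96 h; a higher number here means a weaker inhibitor of growth, a lower number a stronger inhibitor of growth:

Compound 1 `COc1ccc(/C=C(/SCc2ccc(Cl)cc2)C(=O)c2ccc(Br)cc2)cc1` gives 10000 nM.
Compound 2 `COc1ccc(/C=C(/SCc2ccc(Cl)cc2)C(=O)c2ccc(Cl)cc2)cc1` gives 10000 nM.
Compound 3 `COc1ccc(/C=C(/Sc2ccc(C)cc2)C(=O)c2ccc(Cl)cc2)cc1` gives 1000 nM.

Compound 2 stands level with compound 1 at the digits reported, the two together being the highest numbers of the three; the step of no change at the digits printed from compound 1 to compound 2 (within the scatter) is within the scatter, and the step of a 10-fold lower number from compound 2 to compound 3 (1.00 log units; beyond the scatter) is the only one beyond it.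

Compound 4 `COc1ccccc1/C=C(/SCc1ccc(Cl)cc1)C(=O)c1ccc(Cl)cc1` is not yet measured. It differs from compound 2 by 2-methoxyphenyl in place of 4-methoxyphenyl on a double-bonded chain carbon bound to a double-bonded chain carbon.

Neither measured step bears directly on this change: the step from compound 1 to compound 2 alters the halogen on the carbonyl-bearing ring, and the step from compound 2 to compound 3 alters the group on sulfur. The methoxyphenyl is held fixed across compounds 1 to 3, so the data give no guide to moving its methoxy. With nothing to support a shift either way, the expectation is a step of about no change at the digits printed from compound 2 to compound 4 (within the scatter), that is none beyond the scatter.

Compound 4 is therefore estimated at 10000 nM, with a range from 3000 nM to 30000 nM.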

Compound 4, concentration for 50% growth inhibition: 1000 nM
Compound 4: middle estimate off by 10-fold (1.00 log units), on the high side, outside the stated range (below it).
By their numbers in this assay, from the lowest: compounds 3 and 4 (each within the scatter of the next); then compounds 1 and 2 (each within the scatter of the next).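

In this assay the place of the methoxy group on this ring matters: 2-methoxyphenyl in place of 4-methoxyphenyl gives a 10-fold lower number from compound 2 to compound 4 (1.00 log units; beyond the scatter), although the two compounds have the same atoms, joined differently. Compounds 1 to 3 all carry 4-methoxyphenyl, so they could not show that this place on a double-bonded chain carbon bound to a double-bonded chain carbon responds to a change of arrangement alone. Nothing available explains the shift.

On these data alone, it remains open whether 3-methoxyphenyl, or an amine or a hydroxyl group in place of the methoxy on the 2-methoxyphenyl ring, would hold the lower number. Also open, as far as these compounds go, is whether 2-methoxyphenyl would combine with the 4-methylphenyl on sulfur of compound 3 to lower the number further.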